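Shortening the chain and cyclising the amine on the piperidine

A few compounds are considered here, and "the series" means these few. Any claim that something is new, unique, unknown or untested is made for them only; others in the source may bear on it.

Compound 2 `C[C@@H](NCC1CCN(CCCc2c[nH]c3ccc(-n4cnnc4)cc23)CC1)c1ccccc1` stands second highest of the three numbers measured in an assay on CHO cells for displacement of a labelled ligand from 5-hydroxytryptamine receptor 1B (Homo sapiens) (a higher number here means a weaker inhibitor, a lower number a stronger inhibitor), where compound 2 gives 14 nM. Its nearest neighbour is compound 1 `CN(CC1CCN(CCCc2c[nH]c3ccc(-n4cnnc4)cc23)CC1)C(=O)Nc1ccccc1`, which in this assay gives 6.2 nM; compound 3 `c1ccc(C2CCCCN2C2CCN(CCCc3c[nH]c4ccc(-n5cnnc5)cc34)CC2)cc1` lies furthest away and in this assay gives 410 nM. The change now considered leads to compound 4 `O[C@@H]1Cc2ccccc2[C@H]1NC1CCN(CCCc2c[nH]c3ccc(-n4cnnc4)cc23)CC1`: (2-hydroxy-2,3-dihydro-1H-inden-1-yl)amino in place of ((1-phenylethyl)amino)methyl on a saturated ring carbon. Going by the values given here, only one measured step bears on this position, a 2.3-fold higher number from compound 1 to compound 2 (0.35 log units; beyond the scatter), and that was a modest step, so the site has tolerated one exchange on the chain carbon with little cost. Among the compounds with values here, compound 3 shows that a cyclic amine placed directly on the ring carbon can carry a much higher number, but no step between compound 2 and compound 3 is on record. Compound 4 is therefore expected to show a moderate rise, a 3.2-fold higher number from compound 2 to compound 4 (0.51 log units; beyond the scatter), and its estimated value is 45 nM, within a range from 10 nM to 200 nM.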

Compound 4, half-maximal inhibitory concentration: 210 nM
Compound 4: the middle estimate sits 4.7-fold (0.67 log units) below what was measured; the measured number lies above the stated range.
By their numbers in this assay, from the lowest: compound 1; then compound 2; then compounds 4 and 3 (each within the scatter of the next).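

In this assay the exchange gives a 15-fold higher number from compound 2 to compound 4 (1.18 log units; beyond the scatter), a large step, so this position on the saturated ring carbon is far less forgiving than the modest 2.3-fold higher number from compound 1 to compound 2 (0.35 log units; beyond the scatter) had suggested. With compound 4 at 210 nM and compound 3 at 410 nM, within the scatter of each other, both compounds that carry a ring-bearing amine directly on that ring carbon now have numbers well above those of compound 1 and compound 2. No measurement shown here explains the loss.

The step removes the methylene link, closes a five-membered ring and adds a hydroxyl all at once, so the share of each remains unresolved. A ((2-hydroxy-2,3-dihydro-1H-inden-1-yl)amino)methyl group, or a (2,3-dihydro-1H-inden-1-yl)amino group without the hydroxyl, would separate these contributions.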